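Swapping the Aryl Group on a Shared Pyridinone Core

The compounds below may be only part of what the source reports. "The series", "measured", "known", "first", "only" and "open" are said of these compounds alone.

Of the compounds shown here, two with a common core have been measured in a functional assay for inhibition, tested at 40 ug/mL; a lower number here means a weaker effect, a higher number a stronger effect of the compound at the concentration tested. Compound 1 `COc1ccc(-c2cc(-c3cc(C(C)C)c(O)cc3C)[nH]c(=O)c2C#N)cc1` gives 35% in this assay. Compound 2 `Cc1cc(O)c(C(C)C)cc1-c1cc(-c2ccco2)c(C#N)c(=O)[nH]1` gives 42.5% in this assay. Among the measured compounds shown here, the single step between them, a number 7.5 percentage points higher from compound 1 to compound 2 (within the scatter), is within the scatter, so the two values cannot be set apart, and compound 2 stands no further from compound 1 than repeated measurements of one compound would.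

Compound 3 `Cc1cc(O)c(C(C)C)cc1-c1cc(-c2ccccc2[N+](=O)[O-])c(C#N)c(=O)[nH]1` is not yet measured. Its difference from compound 2 is 2-nitrophenyl in place of furan-2-yl on an aromatic carbon. For the measured compounds named here, the only measured step that bears on this change is the exchange of the group at the same position from compound 1 to compound 2, which moved this assay by a number 7.5 percentage points higher from compound 1 to compound 2 (within the scatter), within the scatter. On that basis no step beyond the scatter is expected from compound 2 to compound 3, and the expected change is a number 4.5 percentage points lower from compound 2 to compound 3 (within the scatter). Compound 3 is therefore estimated at 38% in this assay, with a range from 20% to 56%.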

Compound 3, a percentage reported as inhibition, at one concentration (the size of the read-out at that concentration, not a potency): 25.5%
The estimate for compound 3 lay 12.5 percentage points above the measured number; the measured number falls inside the stated range.
By their numbers in this assay, from the lowest: compounds 3, 1 and 2 (each within the scatter of the next, the first and the last beyond it).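

In this assay, the group at this position on the shared core is shown for the first time to matter: 2-nitrophenyl in place of furan-2-yl gives a number 17 percentage points lower from compound 2 to compound 3 (beyond the scatter), the first step here to pass beyond the scatter, though only a modest one. Set against the other six-membered aromatic ring, 2-nitrophenyl in place of 4-methoxyphenyl gives a number 9.5 percentage points lower from compound 1 to compound 3 (within the scatter), so of the three pairs only compound 2 and compound 3 can be told apart in this assay. Nothing measured here accounts for that difference.

The compounds shown leave open whether the step follows the nitro group, its place on the phenyl ring or the exchange of a five-membered ring for a six-membered one, and a plain phenyl or a 2-aminophenyl at this position would help to separate these readings. On these data alone, each compound also stands at a single concentration, so how these read-outs relate to potency remains unknown, as does the effect of any change elsewhere on the core, such as at the isopropyl group or the nitrile.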